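Rearranging the bicyclic tail of compound 3

The source may hold more compounds than are shown below. What is called first, only, known or untested is meant among the compounds shown, and "the series" means these compounds.

Measured so far:
compound 1 `O=C1[C@@H](NS(=O)(=O)c2ccc(-c3ccccn3)s2)CCN1Cc1cc2[nH]cccc-2n1`, 8%
compound 2 `O=C1[C@@H](NS(=O)(=O)c2cc3ccc(Cl)nc3s2)CCN1Cc1cc2cc[nH]cc-2n1`, 50%
compound 3 `O=C1[C@@H](NS(=O)(=O)c2ccc(-c3ccon3)s2)CCN1Cc1cc2c[nH]ccc-2n1`, 17%

These values come from an assay on isolated protein for inhibition of coagulation factor X (Oryctolagus cuniculus), tested at 1 uM; on this read-out lower numbers stand for less inhibition and higher numbers for more inhibition at the one concentration tested (going by the name of the read-out). Compound 3 stands second highest of the three; its value and that of compound 1 lie within the scatter of each other, while compound 2 stands beyond the scatter above it.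

Compound 4 `O=C1[C@@H](NS(=O)(=O)c2ccc(-c3ccon3)s2)CCN1Cc1cc2cc[nH]cc-2n1` has the same atoms as compound 3, joined differently:

a group of 9 heavy atoms (7 carbon, 2 nitrogen; one five-membered aromatic ring with 1 hetero atom, one six-membered aromatic ring with 1 hetero atom) in place of a group of 9 heavy atoms (7 carbon, 2 nitrogen; one five-membered aromatic ring with 1 hetero atom, one six-membered aromatic ring with 1 hetero atom), on a saturated chain carbon bound to an amide-type nitrogen in a ring

Among the measured compounds shown here, no measured pair shows this exact change. Compound 2 carries the same entering group with a different sulfonyl part, so a modest rise is plausible, but the step is expected to stay small. Compound 4 is expected to give 25%, within 8% to 45%. The expected step is a number 8 percentage points higher from compound 3 to compound 4 (within the scatter).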

Compound 4, a percentage reported as inhibition, at one concentration (the size of the read-out at that concentration, not a potency): 49%
For compound 4 the middle estimate is 24 percentage points below the measured one; measured number above the stated range.
By their numbers in this assay, from the lowest: compounds 1 and 3 (each within the scatter of the next); then compounds 4 and 2 (each within the scatter of the next).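

Rejoining the same atoms of the bicyclic group, on the saturated chain carbon bound to an amide-type nitrogen in a ring, gives a number 32 percentage points higher from compound 3 to compound 4 (beyond the scatter), so the way this group is joined matters even though its atom counts do not change. With this entering group in place, changing the sulfonyl part gives a number 1 percentage points lower from compound 2 to compound 4 (within the scatter), so these two sulfonyl parts are not told apart here. No measurement shown accounts for the large step.

Going by these compounds, it remains open whether a plain phenyl ring or an amine at this place would keep this level of inhibition.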